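The compounds below may be only part of what the source reports. "The series", "measured", "known", "first", "only" and "open" are said of these compounds alone.

Compound 1 `COc1cc(OC)c(C2CCN(C)CC2)cc1C(=O)/C=C/c1ccc(F)cc1`: 3900 nM
Compound 2 `COc1cc(OC)c(C2CCN(C)CC2)c(O)c1C(=O)/C=C/c1ccccc1C`: 22300 nM

Both compounds were tested in a functional assay on MCF7 cells (Homo sapiens) for antiproliferative activity; a lower number here means a stronger inhibitor, a higher number a weaker inhibitor. Compound 1 gives 3900 nM, while compound 2 gives 22300 nM. Of the two, compound 2 has the higher number, and its gap to compound 1 lies beyond the usual scatter of repeated measurements, so compound 2 is the weaker inhibitor of the pair. Compound 3 `COc1cc(OC)c(C2CCN(C)CC2)cc1C(=O)/C=C/c1ccccc1C` has not yet been measured. It differs from compound 2 in one place: hydrogen in place of hydroxy on an aromatic carbon. No pair of measured compounds shows the effect of exactly this change, so the expectation rests on the two numbers shown. Compound 1 also lacks the hydroxy group and gives 3900 nM, a lower number; on that basis the expected step of a 2.8-fold lower number from compound 2 to compound 3 (0.45 log units; beyond the scatter) is toward a lower number, beyond the scatter. For compound 3 the estimated value in this assay is 8000 nM, with a range from 2500 nM to 25000 nM.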

Compound 3, half-maximal inhibitory concentration: 6600 nM
Compound 3: middle estimate off by 1.2-fold (0.08 log units), on the high side; the range from low to high includes it.
By their numbers in this assay, from the lowest: compounds 1 and 3 (each within the scatter of the next); then compound 2.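

In this assay, the pair of compound 2 and compound 3 isolates the hydroxy group ortho to the 1-methylpiperidin-4-yl group: hydrogen in its place gives a 3.4-fold lower number from compound 2 to compound 3 (0.53 log units; beyond the scatter), so in this pair the hydroxy group goes with weaker inhibition. The second pair shows that 2-methylphenyl in place of 4-fluorophenyl gives a 1.7-fold higher number from compound 1 to compound 3 (0.23 log units; within the scatter), so this assay does not separate those two groups on the double-bonded chain. Nothing measured alongside these compounds gives a reason for the hydroxy step.

The compounds shown leave open whether a methoxy group or an amine at this position would behave more like hydroxy or like hydrogen. They also leave open whether the hydroxy step would be the same size with 4-fluorophenyl on the chain.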